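Compound 1 to compound 4: methoxy for chloro

The source may hold more compounds than are shown below. What is called first, only, known or untested is meant among the compounds shown, and "the series" means these compounds.

Values in a functional assay on MCF7 cells (Homo sapiens) for antiproliferative activity, read by MTT assay, with a stated time of 72 h; on this read-out higher numbers stand for weaker inhibition and lower numbers for stronger inhibition:
- compound 1 `COc1ccc(N2C(=O)COc3ccc(-c4cnc(Cl)c(NS(=O)(=O)c5ccc(F)cc5)c4)cc32)cc1`: 36000 nM
- compound 2 `O=C1COc2ccc(-c3cnc(Cl)c(NS(=O)(=O)c4ccc(F)cc4)c3)cc2N1`: > 40000 nM (a limit)
- compound 3 `Cc1ccc(N2C(=O)COc3ccc(-c4cnc(Cl)c(NS(=O)(=O)c5ccc(F)cc5)c4)cc32)cc1`: 32600 nM

Compound 1 stands level with compound 3: a 1.1-fold lower number from compound 1 to compound 3 (0.04 log units; within the scatter). Compound 2 is reported only as a limit.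

Compound 4 `COc1ccc(N2C(=O)COc3ccc(-c4cnc(OC)c(NS(=O)(=O)c5ccc(F)cc5)c4)cc32)cc1` differs from compound 1 on the six-membered aromatic ring with 1 nitrogen: methoxy in place of chloro on an aromatic carbon.

The other measured steps are an at least 1.1-fold higher number from compound 1 to compound 2 (0.04 log units; that floor lies within the scatter) and an at least 1.2-fold lower number from compound 2 to compound 3 (0.08 log units; that floor lies within the scatter). All three stay within the scatter, but none touches the place of this change, so they bear on it only weakly. The estimated step is a 1.4-fold lower number from compound 1 to compound 4 (0.16 log units; within the scatter), and no step beyond the scatter is expected in this assay, though with wide uncertainty. The estimated value for compound 4 is 25000 nM, with an expected range of 7000 nM to 55000 nM.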

Compound 4, half-maximal inhibitory concentration: 8260 nM
For compound 4 the middle estimate is 3.0-fold (0.48 log units) above the measured one; low and high end bracket the measured number.
By their numbers in this assay, from the lowest: compound 4; then compounds 3 and 1 (each within the scatter of the next). At a limit, above all of these: compound 2.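

In this assay this position, next to the ring nitrogen and ortho to a ((4-fluorophenyl)sulfonyl)amino group, responds to substitution: methoxy in place of chloro gives a 4.4-fold lower number from compound 1 to compound 4 (0.64 log units; beyond the scatter) and is the first step in the series shown to clear the scatter. The earlier steps shown here, all made elsewhere on the molecule, did not show this. No data shown account for the size of this step.

On these data alone, it remains open whether an amine or an ethoxy group at this position would go further. As far as these compounds go, whether the step carries over to compound 3 also remains open.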